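This account rests on a few compounds, and the source may have more. Where it says the series, first, only, none or still open, it means among the compounds named here.

In a functional assay on PC-3 cells (Homo sapiens) for cytotoxicity, read by MTT assay (on this read-out lower numbers stand for stronger inhibition and higher numbers for weaker inhibition), compound 3 `C[Se]/C(=N\C(=O)c1ccc(Cl)cc1)NC(=O)c1ccc(Cl)cc1` is the only one of the three measured compounds that yields a number, 7600 nM. Compound 2 `CS/C(=N\C(=O)c1ccc(Cl)cc1)NC(=O)c1ccc(Cl)cc1` reaches only a limit, > 10000 nM. Compound 1 `COc1cc(OC)cc(C(=O)/N=C(/NC(=O)c2cc(OC)cc(OC)c2)[Se]C(C)C)c1` likewise reaches only a limit, > 10000 nM. Among the compounds with values here, the one measured step, an at least 1.3-fold lower number from compound 2 to compound 3 (0.11 log units; that floor lies within the scatter), has a floor within the scatter and is bounded by the limit of > 10000 nM in this assay, at which 2 of the 3 values shown sit. Compound 4 `CC(C)[Se]/C(=N\C(=O)c1ccc(Cl)cc1)NC(=O)c1ccc(Cl)cc1` differs from compound 3 by isopropyl in place of methyl on a selenium. Within the data shown here, no measured step matches this change; compound 1, which also carries an isopropyl on a selenium but with other aryl groups, sits at the limit, so little can be read from it. Compound 4 is therefore expected to give 9000 nM, between 4000 nM and 20000 nM, an estimated step of a 1.2-fold higher number from compound 3 to compound 4 (0.07 log units; within the scatter) that may be no more than scatter.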

Compound 4, half-maximal inhibitory concentration: > 10000 nM
Compound 4 ended at the assay's limit; the forecaster's own chance of this, stated with the estimate: 45%; at least 1.1-fold (0.04 log units) between middle value and limit.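

In this assay, isopropyl in place of methyl on a selenium now has a direct reading, with an at least 1.3-fold higher number from compound 3 to compound 4 (0.11 log units; that floor lies within the scatter). Its full size stays hidden because compound 4 sits at a limit, so this change shows no measurable gain over methyl: the limit of > 10000 nM in this assay, at which 3 of the 4 values shown sit. The step from compound 2 to compound 4 cannot be read, as both values are limits.

The compounds shown leave open how an ethyl group or a longer chain on the selenium would read. They also leave open whether an amine in that chain would give a number rather than a limit.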